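A nitrophenyl swap on compound 3

The source may report more compounds than this note shows. Statements on the series, on what has been measured and on what is new or still open speak of the compounds shown alone.

Measured in a functional assay on RS4-11 cells (Homo sapiens) for inhibition, read by CCK-8 assay, with a stated time of 48 h; on this read-out higher numbers stand for weaker inhibition and lower numbers for stronger inhibition:
- Compound 1 `COc1ccc(NC(=O)NCCNS(=O)(=O)c2sccc2-c2ccc(C)cc2Oc2ccc(O)c(O)c2)cc1`: 8200 nM
- Compound 2 `COc1ccc(NC(=S)NCCNS(=O)(=O)c2sccc2-c2ccc(C)cc2Oc2ccc(O)c(O)c2)cc1`: 8300 nM
- Compound 3 `Cc1ccc(-c2ccsc2S(=O)(=O)NCCNC(=O)Nc2cc(Cl)cc(Cl)c2)c(Oc2ccc(O)c(O)c2)c1`: 5100 nM

These three values lie within the scatter of one another, so compound 3 cannot be separated from the other two. The next compound, compound 4 `Cc1ccc(-c2ccsc2S(=O)(=O)NCCNC(=O)Nc2cccc([N+](=O)[O-])c2)c(Oc2ccc(O)c(O)c2)c1`, carries 3-nitrophenyl in place of 3,5-dichlorophenyl on an amide-type nitrogen. For the measured compounds named here, the closest precedent changes the group on this same nitrogen: a 1.6-fold lower number from compound 1 to compound 3 (0.21 log units; within the scatter). The other measured change gives a 1.0-fold higher number from compound 1 to compound 2 (0.01 log units; within the scatter). Going by the values given here, neither step leaves the scatter, and no nitrophenyl compound has been measured yet, so no clear shift is expected in this assay. The estimate therefore means a 1.2-fold higher number from compound 3 to compound 4 (0.07 log units; within the scatter). Compound 4 is expected at 6000 nM, with an estimated range of 2500 nM to 14000 nM.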

Compound 4, half-maximal inhibitory concentration: 9100 nM
Estimate against measurement, compound 4: 1.5-fold (0.18 log units) below; low and high end bracket the measured number.
By their numbers in this assay, from the lowest: compounds 3, 1, 2 and 4 (each within the scatter of the next).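

In this assay the change from 3,5-dichlorophenyl to 3-nitrophenyl on the amide-type nitrogen gives a 1.8-fold higher number from compound 3 to compound 4 (0.25 log units; within the scatter) and adds a nitro-bearing group to those tried at this position. Set against the other compounds, it gives a 1.1-fold higher number from compound 1 to compound 4 (0.05 log units; within the scatter) and also a 1.1-fold higher number from compound 2 to compound 4 (0.04 log units; within the scatter) so the four groups tried here remain indistinguishable on this read-out. No supporting evidence bears on this result. Going by these compounds, whether a phenyl group carrying an amine or a carboxylic acid on this nitrogen would produce a step beyond the scatter stays open.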